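The compounds below may be only part of what the source reports. "The series", "measured", "known", "first", "only" and "open" are said of these compounds alone.

In a toxicity assay on Vero cells (Chlorocebus sabaeus) for cytotoxicity, read by MTT assay (on this read-out lower numbers stand for stronger inhibition and higher numbers for weaker inhibition), compound 3 `CCOC(=O)NC(=O)c1ccsc1NC(=O)c1ccc(S(=O)(=O)N2CCCCC2)cc1` gives 18.6 ug/mL. Compound 1 `COC(=O)NC(=O)c1ccsc1NC(=O)c1ccc(S(=O)(=O)N2CCC(OC)CC2)cc1` gives 18 ug/mL, and the two values lie within the scatter of each other. Compound 2 `CCOC(=O)NC(=O)c1ccsc1NC(=O)c1ccc(S(=O)(=O)N2CCC2)cc1` gives > 64 ug/mL, which is a limit of the assay and not a number.

Compound 4 `CCOC(=O)NC(=O)c1ccsc1NC(=O)c1ccc(S(=O)(=O)N2CCC(OC)CC2)cc1` follows from compound 3 by one change: methoxy in place of hydrogen on a saturated ring carbon, turning piperidin-1-yl into 4-methoxypiperidin-1-yl.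

Within the data shown here, the one measured step in this part of the molecule is an at least 3.4-fold lower number from compound 2 to compound 3 (0.53 log units; beyond the scatter), with piperidin-1-yl in place of azetidin-1-yl. It swaps the ring itself and does not add methoxy, so it bears on the change only loosely. The closer guide differs from compound 4 elsewhere but already carries 4-methoxypiperidin-1-yl: this is compound 1, which sits at 18 ug/mL.

No shift beyond the scatter is therefore expected in this assay. The expected step is a 1.0-fold lower number from compound 3 to compound 4 (0.01 log units; within the scatter). For compound 4 the estimated value is 18 ug/mL, with an expected range from 8 ug/mL to 40 ug/mL.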

Compound 4, half-maximal inhibitory concentration: 21 ug/mL
For compound 4 the middle estimate is 1.2-fold (0.07 log units) below the measured one; measured number inside the range.
By their numbers in this assay, from the lowest: compounds 1, 3 and 4 (each within the scatter of the next). At a limit, above all of these: compound 2.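

In this assay, methoxy in place of hydrogen on a saturated ring carbon, three ring bonds from the ring nitrogen, leaves the number unmoved, with a 1.1-fold higher number from compound 3 to compound 4 (0.05 log units; within the scatter). Methyl in place of hydrogen on the saturated chain carbon bound to an oxygen gives the same picture with 4-methoxypiperidin-1-yl in place, with a 1.2-fold higher number from compound 1 to compound 4 (0.07 log units; within the scatter). With compound 2 at a limit and not a number, 4-methoxypiperidin-1-yl in place of azetidin-1-yl gives an at least 3.0-fold lower number from compound 2 to compound 4 (0.48 log units; beyond the scatter), which runs the same way as an at least 3.4-fold lower number from compound 2 to compound 3 (0.53 log units; beyond the scatter), so among these compounds the shift goes with the ring swap and not with the methoxy.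

On these data alone, whether a hydroxyl, an amine or a carboxylic acid on the same ring carbon would also leave the number in place stays open. So does where pyrrolidin-1-yl would fall.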